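The source may hold more compounds than are shown below. What is called first, only, known or untested is meant among the compounds shown, and "the series" means these compounds.

Values in a functional assay on MOLT-4 cells (Homo sapiens) for antiproliferative activity; a higher number here means a weaker inhibitor, a lower number a stronger inhibitor:
- compound 1 `COc1cc(C(=O)c2sc(-c3ccc(Br)cc3)cc2N)cc(OC)c1OC`: 92 nM
- compound 2 `COc1cc(C(=O)c2sc(-c3ccc(I)cc3)cc2N)cc(OC)c1OC`: 190 nM
- compound 3 `COc1cc(C(=O)c2sc(-c3cccc([N+](=O)[O-])c3)cc2N)cc(OC)c1OC`: not yet measured

Compound 1 stands lowest of the two measured compounds, with compound 2 its nearest neighbour. The next change is 3-nitrophenyl in place of 4-bromophenyl on an aromatic carbon, next to the ring sulfur. Going by the values given here, the only measured step bearing on it is a 2.1-fold higher number from compound 1 to compound 2 (0.31 log units; beyond the scatter), a modest one, with iodo in place of bromo. The new change replaces more of the group, so a larger step towards a higher number is expected in this assay, though one step is thin support. The expected step is a 3.8-fold higher number from compound 1 to compound 3 (0.58 log units; beyond the scatter). For compound 3 the estimate is 350 nM, with an expected range of 90 nM to 1500 nM.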

Compound 3, half-maximal inhibitory concentration: 7.5 nM
Beside the measured number, compound 3's estimate is 47-fold (1.67 log units) above it, outside the stated range (below it).
By their numbers in this assay, from the lowest: compound 3; then compound 1; then compound 2.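

At the position next to the ring sulfur, 3-nitrophenyl in place of 4-bromophenyl gives a 12-fold lower number from compound 1 to compound 3 (1.09 log units; beyond the scatter) in this assay, and 3-nitrophenyl in place of 4-iodophenyl gives a 25-fold lower number from compound 2 to compound 3 (1.40 log units; beyond the scatter). This position therefore allows much larger gains than the halogen exchange alone showed, and replacing the whole aryl group lowers the number rather than raising it. No measured evidence accounts for the gain.

From the compounds shown here alone, the nitro group and its place on the phenyl ring change together, so their shares remain open. 4-nitrophenyl and 3-bromophenyl would separate them.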